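The compounds below may be only part of what the source reports. "The series", "measured", "known", "first", "only" and "open" are said of these compounds alone.

Measured in an ADME assay on microsomes from liver (Canis lupus familiaris) for metabolic stability, read by LC-MS, using NADPH, with a stated time of 10 min, tested at 0.1 uM; on this read-out lower numbers stand for slow clearance and higher numbers for fast clearance:
- compound 1 `O=C(NCCCCn1cccn1)c1cccc(C2SCC(=O)N2c2ccccn2)c1`: 88.9 mL.min-1.g-1
- compound 2 `Cc1ccnc(N2C(=O)CSC2c2cccc(C(=O)NCCCCn3cccn3)c2)c1`: 41.8 mL.min-1.g-1
- compound 3 `O=C(NCCCCc1ccccc1)c1cccc(C2SCC(=O)N2c2ccccn2)c1`: 492 mL.min-1.g-1

Compound 3 is the highest of the three. Compound 4 `CC(F)(F)c1cccc(N2C(=O)CSC2c2cccc(C(=O)NCCCCc3ccccc3)c2)c1` differs from it as follows: a group of 10 heavy atoms (8 carbon, 2 fluorine; one six-membered aromatic ring of carbon only) in place of a group of 6 heavy atoms (5 carbon, 1 nitrogen; one six-membered aromatic ring with 1 hetero atom), on an amide-type nitrogen in a ring. Among the compounds with values here, no measured step replaces the whole pyridin-2-yl group. Within the data shown here, the only change on that group is a 2.1-fold lower number from compound 1 to compound 2 (0.33 log units; beyond the scatter), a modest step. The other measured step, at the far end of the chain, is a 5.5-fold higher number from compound 1 to compound 3 (0.74 log units; beyond the scatter), also modest. Neither gives a firm direction for the new group, so only a small change in this assay is expected, with wide uncertainty. The estimated change is a 1.3-fold higher number from compound 3 to compound 4 (0.12 log units; within the scatter). For compound 4 the estimate is 650 mL.min-1.g-1, with an expected range from 200 mL.min-1.g-1 to 1600 mL.min-1.g-1.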

Compound 4, intrinsic clearance in microsomes: 912 mL.min-1.g-1
The estimate for compound 4 lay 1.4-fold (0.15 log units) below the measured number, and the stated range covers the measured number.
By their numbers in this assay, from the lowest: compound 2; then compound 1; then compounds 3 and 4 (each within the scatter of the next).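

In this assay, the change on the amide-type nitrogen in a ring gives a 1.9-fold higher number from compound 3 to compound 4 (0.27 log units; within the scatter). With the phenyl chain end held constant, this whole-group replacement, which removes the ring nitrogen and the only hydrogen-bond acceptor of the leaving group, does not separate compound 4 from compound 3. No available data bear on the reason for this result.

On these data alone, it remains open whether the same replacement would give a comparable step with the 1H-pyrazol-1-yl chain end of compound 1. Also open, as far as these compounds go, is whether an amine or a carboxylic acid on the new aromatic ring would separate from compound 3.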